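The source may hold more compounds than are shown below. What is called first, only, known or untested is meant among the compounds shown, and "the series" means these compounds.

Measured so far:
compound 1 `N#Cc1cccc(C(=O)NC2CCCC(NC(=O)c3ccccn3)C2)c1` — 1540 nM
compound 2 `COc1ccc(C(=O)N[C@H]2CCC[C@H](NC(=O)c3cccc(Cl)c3)C2)cc1` — 674 nM

In an assay on HEK293 cells for displacement of a labelled ligand from metabotropic glutamate receptor 5 (Homo sapiens), read by scintillation counting, with a stated time of 60 min (on this read-out higher numbers stand for weaker inhibition and lower numbers for stronger inhibition), compound 1 gives 1540 nM, the higher of the two numbers; compound 2 gives 674 nM, and the gap between the two lies beyond the scatter.

Compound 3 `N#Cc1cccc(C(=O)N[C@@H]2CCC[C@@H](NC(=O)c3ccccn3)C2)c1` keeps the atoms and bonds of compound 1: the two compounds have the same atoms and bonds; at least one stereo element is drawn with a configuration in one of them and without one in the other: 2 of 2 stereo elements differ; a stereocentre at a saturated ring carbon is drawn without a configuration in compound 1 and R in compound 3; a stereocentre at a saturated ring carbon is drawn without a configuration in compound 1 and R in compound 3. Compound 1 is drawn without configuration, so it may represent a mixture of which compound 3 is one defined isomer. Going by the values given here, no step between measured compounds shows what fixing both ring stereocentres does. A modest move toward a lower number is expected, with wide uncertainty, since a single isomer drawn from a mixture may carry its binding or may not. The step from compound 1 to compound 3 is expected at a 1.9-fold lower number from compound 1 to compound 3 (0.28 log units; within the scatter). Compound 3 is estimated at 800 nM, within 250 nM to 3500 nM.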

Compound 3, inhibition constant: 1280 nM
For compound 3 the middle estimate is 1.6-fold (0.20 log units) below the measured one, within the range that was stated.
By their numbers in this assay, from the lowest: compounds 2, 3 and 1 (each within the scatter of the next, the first and the last beyond it).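

In this assay, defining both ring stereocentres as R gives a 1.2-fold lower number from compound 1 to compound 3 (0.08 log units; within the scatter), so this step does not separate compound 3 from the undefined form. It is the first reading at these stereocentres in the series, and it is limited by what is being compared: the fact that one of compounds 1 and 3 is drawn with a defined configuration and the other without, at the place where they differ

Going by these compounds, how other configurations at these two ring carbons compare with compound 3 remains open. Also open, on these data alone, is how a carboxylic acid or an amine in place of the nitrile of compound 3 would read in this assay.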